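A Halogen Swap Repeated on a Second Core

This account rests on a few compounds, and the source may have more. Where it says the series, first, only, none or still open, it means among the compounds named here.

Of the compounds shown here, three of one series have been measured in a functional assay on HT-1080 cells (Homo sapiens) for cytotoxicity, read by MTT assay, with a stated time of 72 h; a lower number here means a stronger inhibitor, a higher number a weaker inhibitor. Compound 1 `COc1cccc(/C=C2\CCC/C(=C\c3ccc(Cl)cc3)C2=O)c1OC` gives 11100 nM in this assay. Compound 2 `COc1cccc(/C=C2\CCC/C(=C\c3ccccc3Br)C2=O)c1OC` gives 10800 nM in this assay. Compound 3 `COc1ccc(/C=C2\CCC/C(=C\c3ccc(Cl)cc3)C2=O)cc1OC` gives 4800 nM in this assay, the lowest of the three numbers, and both other values stand beyond the scatter from it.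

Compound 3 is built from the same atoms as compound 1, joined differently; the difference between the two cores is not broken down here. Within the core of compound 1, the change from compound 1 to compound 2 is 2-bromophenyl in place of 4-chlorophenyl on a double-bonded chain carbon bound to a double-bonded ring carbon. Its effect in this assay was a 1.0-fold lower number from compound 1 to compound 2 (0.01 log units; within the scatter), so the two values cannot be ordered.

Compound 4 `COc1ccc(/C=C2\CCC/C(=C\c3ccccc3Br)C2=O)cc1OC` has not yet been measured in this assay. It differs from compound 3 by 2-bromophenyl in place of 4-chlorophenyl on a double-bonded chain carbon bound to a double-bonded ring carbon. The place of the change is described in the same words as for compound 1 and compound 2, so it is the same change carried onto the core of compound 3.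

The expected step is no change at the digits printed from compound 3 to compound 4 (within the scatter), resting on the earlier, flat step a 1.0-fold lower number from compound 1 to compound 2 (0.01 log units; within the scatter) because that step stayed within the scatter. Within the data shown here, the number expected for compound 4 in this assay is therefore 4800 nM, with a likely range from 2000 nM to 11000 nM; the single precedent is one pair only, so the range is kept wide.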

Compound 4, half-maximal inhibitory concentration: 8400 nM
Compound 4: middle estimate off by 1.8-fold (0.24 log units), on the low side, and the stated range covers the measured number.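

In this assay, placing 2-bromophenyl where 4-chlorophenyl stood on the core of compound 3 gave a 1.8-fold higher number from compound 3 to compound 4 (0.24 log units; within the scatter), so this pair cannot be ordered, just as the matching pair on the core of compound 1 could not. Set side by side, the two steps cannot be told apart: the same change on two cores in this assay, a 1.0-fold lower number (0.01 log units; within the scatter) from compound 1 to compound 2 and a 1.8-fold higher number (0.24 log units; within the scatter) from compound 3 to compound 4, 1.8-fold (0.25 log units) apart, within the scatter of two such steps. On these two cores, then, the change has no effect that stands clear of the scatter, but this rests on two pairs in a single cell assay and does not show that the two steps are identical, or that the change would stay flat on another core or in another assay.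

The compounds shown leave open what would happen if an amine or a carboxylic acid took the place of the chlorine or bromine on the phenyl group, since every such group here carries a single halogen. They also leave open whether the same flat result would hold on a core with a longer chain in place of the methoxy groups, and so how far this one precedent can be carried through the series.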